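Benzofuranyl for furanyl on two nucleoside cores

The compounds below may be only part of what the source reports. "The series", "measured", "known", "first", "only" and "open" are said of these compounds alone.

Compound 2 `Cc1ncnc2c1c(-c1ccoc1)cn2[C@@H]1O[C@H](CO)[C@@H](O)[C@H]1O` and compound 1 `Cc1ncnc2c1c(-c1cc3ccccc3o1)cn2[C@@H]1O[C@H](CO)[C@@H](O)[C@H]1O` share one core, while compound 3 `Nc1nc(N)c2c(-c3ccoc3)cn([C@@H]3O[C@H](CO)[C@@H](O)[C@H]3O)c2n1` and compound 4 `Nc1nc(N)c2c(-c3cc4ccccc4o3)cn([C@@H]3O[C@H](CO)[C@@H](O)[C@H]3O)c2n1` share another. How the core of compound 3 differs from the core of compound 2 is not broken down here. In an ADME assay on BJ cells (Homo sapiens), read by MTT assay, with a stated time of 72 h (on this read-out higher numbers stand for weaker inhibition and lower numbers for stronger inhibition), compound 2 gives 89200 nM, and in this assay compound 1 gives 93900 nM. The change between them is 1-benzofuran-2-yl in place of furan-3-yl on an aromatic carbon, and it gives a 1.1-fold higher number from compound 2 to compound 1 (0.02 log units; within the scatter). Compound 3 reaches only a limit of this assay, > 100000 nM. That reading is the limit of > 100000 nM in this assay, at which 1 of the 3 values shown sits. Compound 4 carries the same change on the second core, (1-benzofuran-2-yl in place of furan-3-yl on an aromatic carbon), and the place is described in the same words for both pairs, so the two changes are the same change. Because a 1.1-fold higher number from compound 2 to compound 1 (0.02 log units; within the scatter) stays within the scatter, the step from compound 3 to compound 4 in this assay is expected to be a step that the limit leaves unreadable from compound 3 to compound 4. Compound 4 is therefore estimated at 115000 nM in this assay, with an expected range from 60000 nM to 250000 nM, and most probably again only a limit will be reported.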

Compound 4, half-maximal inhibitory concentration: > 100000 nM
Compound 4 ended at the assay's limit (the forecaster's own chance of this, stated with the estimate: 75%); the middle value does not contradict the limit.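

In this assay compound 3 and compound 4 both stand at a limit of the assay, not at a number, so no step can be read between them: the limit of > 100000 nM in this assay, at which 2 of the 4 values shown sit.

The compounds shown leave open whether 1-benzofuran-2-yl in place of furan-3-yl changes the reading on the core of compound 3 any more than it does on the core of compound 2.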